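Shortening the ether side chain of a flavone series

This account rests on a few compounds, and the source may have more. Where it says the series, first, only, none or still open, it means among the compounds named here.

Compound 2 `CC(C)(C)c1cc(-c2cc(=O)c3ccc(OCc4ccc(Cl)cc4)cc3o2)cc(C(C)(C)C)c1O` carries a 4-chlorobenzyl ether on the shared core. Among the measured compounds shown here, in a functional assay for inhibition (a lower number here means a stronger inhibitor, a higher number a weaker inhibitor), compound 2 gives 7000 nM, the highest of the two numbers measured so far. Compound 1 `CCOC(=O)CCCCOc1ccc2c(=O)cc(-c3cc(C(C)(C)C)c(O)c(C(C)(C)C)c3)oc2c1`, which bears a 3-(ethoxycarbonyl)propyl group at the same oxygen, gives 3000 nM in this assay, and the step of a 2.3-fold higher number from compound 1 to compound 2 (0.37 log units; beyond the scatter) shows that the chlorinated aromatic group sits at the weaker end of what has been seen. Compound 3 `CCOC(=O)COc1ccc2c(=O)cc(-c3cc(C(C)(C)C)c(O)c(C(C)(C)C)c3)oc2c1` is the next, unmeasured member. It differs from compound 2 by ethoxycarbonyl in place of 4-chlorophenyl on a saturated chain carbon bound to an oxygen on an aromatic ring. For the measured compounds named here, only the single step from compound 1 to compound 2 bears on this change, and it runs the opposite way, so a modest reversal is expected, with the shorter ester chain of compound 3 left uncertain against the longer one of compound 1. Compound 3 is therefore expected to give 3500 nM, within 1500 nM to 8000 nM, an estimated step of a 2.0-fold lower number from compound 2 to compound 3 (0.30 log units; within the scatter).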

Compound 3, half-maximal inhibitory concentration: 3000 nM
Compound 3: middle estimate off by 1.2-fold (0.07 log units), on the high side; the measured number falls inside the stated range.
By their numbers in this assay, from the lowest: compounds 1 and 3 (each within the scatter of the next); then compound 2.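

In this assay, putting ethoxycarbonyl in place of 4-chlorophenyl gives a 2.3-fold lower number from compound 2 to compound 3 (0.37 log units; beyond the scatter), so both ester-bearing side chains now stand apart from the 4-chlorobenzyl ether, where before only one did. Ethoxycarbonyl in place of 3-(ethoxycarbonyl)propyl gives no change at the digits printed from compound 1 to compound 3 (within the scatter), so across these two compounds the length of the chain leading to the ester does not register at this oxygen. No measurement shown here speaks to why either step comes out as it does.

Going by these compounds, it remains open whether the ester itself counts, which a carboxylic acid or a plain butyl chain on the same oxygen would help to settle. On these data alone, it is equally open whether the chlorine or the aromatic ring of the 4-chlorophenyl group carries the step, a question for an unsubstituted benzyl ether.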